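Exchanging the Aromatic Group on a Sulfonyl Sulfur

This account rests on a few compounds, and the source may have more. Where it says the series, first, only, none or still open, it means among the compounds named here.

Measured compounds:
Compound 1 `O=S(=O)(c1ccccc1)c1ccc(CNS(=O)(=O)N2Cc3ccncc3C2)cc1`: > 2000 nM (a limit of the assay, not a number)
Compound 2 `O=C(NCc1ccc(S(=O)(=O)c2cncc(C(F)(F)F)c2)cc1)N1Cc2ccncc2C1`: 10 nM

Both compounds were tested in a functional assay on A2780 cells (Homo sapiens) for cytotoxicity, read by sulforhodamine B assay, with a stated time of 72 h; a lower number here means a stronger inhibitor, a higher number a weaker inhibitor. Among the compounds with values here, compound 2 gives 10 nM, the only actual number available and thus the sole numerical reference point. The other result is only a limit: the limit of > 2000 nM in this assay, at which 1 of the 2 values shown sits. Within the data shown here, no measured step links compound 1 and compound 2 through a single change, so these two results offer no direct guide to the next exchange.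

Compound 3 `O=C(NCc1ccc(S(=O)(=O)C2CCC(F)(F)CC2)cc1)N1Cc2ccncc2C1` keeps the rest of compound 2 but carries 4,4-difluorocyclohexyl in place of 5-(trifluoromethyl)pyridin-3-yl on a sulfonyl sulfur. The new group is a six-membered non-aromatic ring of carbon only, whereas the group that leaves is a six-membered aromatic ring with 1 hetero atom.

Among the measured compounds shown here, with no measured precedent for this exchange, no change beyond the scatter is expected in this assay, although any drift is expected to lean towards weaker inhibition. The estimated step is a 1.5-fold higher number from compound 2 to compound 3 (0.18 log units; within the scatter). The expected value for compound 3 is 15 nM, with an estimated range from 4 nM to 60 nM.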

Compound 3, half-maximal inhibitory concentration: 13 nM
For compound 3 the middle estimate is 1.2-fold (0.06 log units) above the measured one; the range from low to high includes it.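

In this assay, placing 4,4-difluorocyclohexyl in place of 5-(trifluoromethyl)pyridin-3-yl on a sulfonyl sulfur gives a 1.3-fold higher number from compound 2 to compound 3 (0.11 log units; within the scatter). Within the data shown here, this is the first measured step at this place, and it shows that, with the rest of compound 2 kept, a six-membered aromatic ring with 1 hetero atom can give way to a six-membered non-aromatic ring of carbon only without a change beyond the scatter, even though the entering group has fewer heavy atoms and 0 hydrogen-bond acceptors against 1. Nothing measured here accounts for this result.

Both groups shown on this sulfonyl sulfur in compound 2 and compound 3 carry fluorine, so the compounds shown leave open how a plain cyclohexyl ring, or a ring bearing an amine or a carboxylic acid, would behave at this place. Among these compounds, compound 1 is a limit of the assay at > 2000 nM, and no measured step links it to the other compounds.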